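Aryl variation on the saturated ring carbon: cytotoxicity notes

A few compounds are considered here, and "the series" means these few. Any claim that something is new, unique, unknown or untested is made for them only; others in the source may bear on it.

Measured so far:
compound 1 `COc1cc(N2C(N)=C(C#N)C(c3ccccc3O)C3=C2CC(C)(C)CC3=O)cc(OC)c1OC` — 10%
compound 2 `COc1cc(N2C(N)=C(C#N)C(c3ccc(C)o3)C3=C2CC(C)(C)CC3=O)cc(OC)c1OC` — 50%

In a functional assay on Ehrlich cells (Mus musculus) for cytotoxicity, tested at 100 ug/mL (a lower number here means a weaker effect, a higher number a stronger effect of the compound at the concentration tested), compound 1 gives 10% and compound 2 gives 50%. Going by the values given here, compound 2 holds the higher of the two numbers; the only other number, that of compound 1, lies lower by a step beyond the scatter, a number 40 percentage points higher from compound 1 to compound 2 (beyond the scatter). Compound 3 `COc1cc(N2C(N)=C(C#N)C(c3ccc(O)cc3)C3=C2CC(C)(C)CC3=O)cc(OC)c1OC` is not yet measured. It differs from compound 2 in one place: 4-hydroxyphenyl in place of 5-methylfuran-2-yl on a saturated ring carbon. Among the compounds with values here, the single measured step that bears on this change is a number 40 percentage points higher from compound 1 to compound 2 (beyond the scatter), where 5-methylfuran-2-yl replaced 2-hydroxyphenyl on the same saturated ring carbon and the number rose by a large amount. Compound 3 runs that exchange in the opposite direction, bringing a hydroxyphenyl group back in place of the furan, although 4-hydroxyphenyl is not the same group as 2-hydroxyphenyl, so the size of the return is uncertain. A drop beyond the scatter is therefore expected, estimated as a number 30 percentage points lower from compound 2 to compound 3 (beyond the scatter). For compound 3 the expected value in this assay is 20%, with a range from 5% to 45%.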

Compound 3, a percentage reported as activity, at one concentration (the size of the read-out at that concentration, not a potency): 100%
Compound 3: middle estimate off by 80 percentage points, on the low side; the measured number lies above the stated range.
By their numbers in this assay, from the lowest: compound 1; then compound 2; then compound 3.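

In this assay, 4-hydroxyphenyl in place of 5-methylfuran-2-yl gives a number 50 percentage points higher from compound 2 to compound 3 (beyond the scatter), so the furan is not the best group among those shown on this saturated ring carbon, and a hydroxyphenyl group here does not by itself go with a low number. The exchange between the two hydroxyphenyl groups alone gives a number 90 percentage points higher from compound 1 to compound 3 (beyond the scatter), so the read-out at this carbon depends on which hydroxyphenyl isomer is present, and the furan of compound 2 falls between the two isomers. Nothing available explains why the two isomers differ so widely or why compound 3 stands above the furan.

The compounds shown leave open whether the hydroxy group of 4-hydroxyphenyl is itself needed, which a 4-methoxyphenyl, 4-aminophenyl or unsubstituted phenyl group at the same carbon would address, and where a 3-hydroxyphenyl group would fall relative to the two isomers. Each number also comes from a single concentration, so the order of compound 1, compound 2 and compound 3 gives no potency and may not hold at lower concentrations.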